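Methyl for bromo on the aryl ring, two cores

The source may report more compounds than this note shows. Statements on the series, on what has been measured and on what is new or still open speak of the compounds shown alone.

Compound 1 `O=C1/C(=C/c2cccc(Br)c2)CCCc2ccccc21` gives 51000 nM in a functional assay on L1210 cells (Mus musculus) for inhibition; a lower number here means a stronger inhibitor, a higher number a weaker inhibitor. Compound 2 `Cc1cccc(/C=C2\CCCc3ccccc3C2=O)c1` differs from it by methyl in place of bromo on an aromatic carbon; in this assay compound 2 gives 54400 nM, and the step is a 1.1-fold higher number from compound 1 to compound 2 (0.03 log units; within the scatter). Compound 3 `O=C1CCCCC/C1=C\c1ccc(Br)cc1` has another core; the difference between the two cores is not broken down here. In this assay compound 3 gives 68400 nM, within the scatter of both compound 1 and compound 2. Compound 4 `Cc1ccc(/C=C2\CCCCCC2=O)cc1`, not yet measured, differs from compound 3 by methyl in place of bromo on an aromatic carbon. This is the same kind of change as that from compound 1 to compound 2, though there the new group sits meta to a large group and here para to a group of 9 heavy atoms. The expectation rests on the matched pair, where a 1.1-fold higher number from compound 1 to compound 2 (0.03 log units; within the scatter) lay within the scatter. The expected step is a 1.1-fold higher number from compound 3 to compound 4 (0.02 log units; within the scatter). Compound 4 is expected to give about 72000 nM in this assay, within 36000 nM to 145000 nM.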

Compound 4, half-maximal inhibitory concentration: > 500000 nM
Compound 4 ended at the assay's limit; the forecaster's own chance of this, stated with the estimate: 10%; middle value at least 6.9-fold (0.84 log units) from the limit.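

Methyl in place of bromo gives an at least 7.3-fold higher number from compound 3 to compound 4 (0.86 log units; beyond the scatter), so the change does not carry over unchanged from one core to the other in this assay: the same change on two cores in this assay, a 1.1-fold higher number (0.03 log units; within the scatter) from compound 1 to compound 2 and an at least 7.3-fold higher number (0.86 log units; beyond the scatter) from compound 3 to compound 4, at least 6.8-fold (0.83 log units) apart, beyond the scatter of two such steps

For compound 4, > 500000 nM is a limit of the assay and not a number.

The two pairs differ both in the core and in where the group sits on the aromatic ring, and they do not show which of these separates the two steps.

Open, on these data alone, is whether the same gap appears with the group at one shared place on both cores. Also open, as far as these compounds go, is how other groups on the ring, such as chloro, methoxy or an amine, behave on each core.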